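The source may hold more compounds than are shown below. What is called first, only, known or untested is meant among the compounds shown, and "the series" means these compounds.

Measured in a functional assay on CCRF-CEM cells (Homo sapiens) for cytotoxicity; a lower number here means a stronger inhibitor, a higher number a weaker inhibitor:

compound 1 `O=C(/C=C/c1ccc(Cl)cc1)c1ccc(N2C(=O)C=CC2=O)cc1` — 7500 nM
compound 2 `O=C(/C=C/c1ccc(Cl)c(Cl)c1)c1ccc(N2C(=O)C=CC2=O)cc1` — 7700 nM
compound 3 `COc1ccc(/C=C/C(=O)c2ccc(N3C(=O)C=CC3=O)cc2)cc1` — 8400 nM

Compound 3 gives the highest of the three numbers in this assay, but its distance to the others is small: a 1.1-fold higher number from compound 1 to compound 3 (0.05 log units; within the scatter) and a 1.1-fold higher number from compound 2 to compound 3 (0.04 log units; within the scatter) both lie within the scatter, so the three measured compounds cannot be told apart on these values.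

Compound 4 `COc1ccc(/C=C/C(=O)c2ccc(N3C(=O)C=CC3=O)cc2)cc1OC` is not yet measured. It differs from compound 3 in one place: methoxy in place of hydrogen on an aromatic carbon.

Among the measured compounds shown here, three measured steps bear on this change. The closest analogue is the addition of a second substituent to the ring carried on the double-bonded chain: a 1.0-fold higher number from compound 1 to compound 2 (0.01 log units; within the scatter). The exchange of one ring substituent for another gave a 1.1-fold higher number from compound 1 to compound 3 (0.05 log units; within the scatter), and the exchange of the whole ring gave a 1.1-fold higher number from compound 2 to compound 3 (0.04 log units; within the scatter). None of these moved the number beyond the scatter. On that record, adding a further methoxy group to the same ring is expected to give no step beyond the scatter; the expected step is a 1.1-fold lower number from compound 3 to compound 4 (0.02 log units; within the scatter).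

Compound 4 is therefore estimated at 8000 nM in this assay, with a range from 4000 nM to 16000 nM.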

Compound 4, half-maximal inhibitory concentration: 220000 nM
Estimate against measurement, compound 4: 28-fold (1.44 log units) below; measured number outside the range, above it.
By their numbers in this assay, from the lowest: compounds 1, 2 and 3 (each within the scatter of the next); then compound 4.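

In this assay, among the compounds shown here, methoxy in place of hydrogen on an aromatic carbon, ortho to a methoxy group and meta to a large group, gives a 26-fold higher number from compound 3 to compound 4 (1.42 log units; beyond the scatter) and is the first step beyond the scatter. For the compounds shown here, the flat record of the earlier compounds therefore does not extend to this change: chloro in place of hydrogen on the same ring gave a 1.0-fold higher number from compound 1 to compound 2 (0.01 log units; within the scatter) within the scatter, so across these two pairs the outcome of adding a second ring substituent depends on the group that enters or on the compound that receives it. The compounds shown contain no measurement that explains the size of this step.

From the compounds shown here alone, whether the large step belongs to methoxy itself remains open, since a hydroxyl group, a fluorine atom or an ethoxy group at this place on compound 3 would test how far it depends on the entering group. Also open, going by these compounds, is whether methoxy at this place gives a step of similar size on compound 1, where the neighbouring group is chloro.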